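The source may report more compounds than this note shows. Statements on the series, on what has been measured and on what is new or still open speak of the compounds shown alone.

Of the compounds shown here, three that share one core have been measured in a physicochemical assay for lipophilicity, at pH 7.4; a higher number here means a more lipophilic compound, a lower number a more polar compound. Compound 1 `CC(C)CN(c1cccc(F)c1)S(=O)(=O)c1ccc2c(c1)C(=O)CC(C1CCOCC1)O2` gives 3.5. Compound 2 `Cc1ccc(NS(=O)(=O)c2ccc3c(c2)C(=O)CC(C2CCOCC2)O3)c(C)c1` gives 2.75, and compound 3 `CCc1ccc(N(CC(C)C)S(=O)(=O)c2ccc3c(c2)C(=O)CC(C2CCN(S(C)(=O)=O)CC2)O3)cc1` gives 3.31. Among these three numbers compound 1 stands highest: its gap to compound 3 lies within the scatter of repeated measurements, so those two cannot really be told apart, whereas its gap to compound 2 lies beyond the scatter.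

Compound 4 `CC(C)CN(c1ccc(F)cc1)S(=O)(=O)c1ccc2c(c1)C(=O)CC(C1CCOCC1)O2` has not yet been measured in this assay. It differs from compound 1 only in how the same atoms are joined together: 4-fluorophenyl in place of 3-fluorophenyl on a sulfonamide nitrogen Nothing is added and nothing is taken away; only the place of the fluorine within the fluorophenyl group changes. For a rearrangement of this kind a small step, if any, is expected in this assay, with no clear direction. The expected step is no change at the digits printed from compound 1 to compound 4 (within the scatter), within the scatter. Compound 4 is therefore estimated at 3.5 in this assay, with a range from 3.2 to 3.8.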

Compound 4, distribution coefficient: 3.48
Compound 4: middle estimate off by 0.02 log units, on the high side; low and high end bracket the measured number.
By their numbers in this assay, from the lowest: compound 2; then compounds 3, 4 and 1 (each within the scatter of the next).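

Replacing 3-fluorophenyl with 4-fluorophenyl on a sulfonamide nitrogen gives, in this assay, a number 0.02 log units lower from compound 1 to compound 4 (within the scatter). Among these compounds, this is the first pair that differs in one place only, so a single change at this position can now be read on its own. Here, moving the fluorine around the aromatic ring leaves no difference that can be told apart from the scatter of repeated measurements, and no measurement at hand offers an explanation for this.

From the compounds shown here alone, what an amine or a carboxylic acid on this aromatic ring in place of the fluorine would do to the number remains open. Going by these compounds, it is also open whether moving the fluorine would matter as little with another part of the molecule changed.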